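Swapping one indole group on a shared core

The compounds below may be only part of what the source reports. "The series", "measured", "known", "first", "only" and "open" are said of these compounds alone.

Among the measured compounds shown here, in a functional assay on HeLa cells (Homo sapiens) for inhibition, read by CCK-8 assay, with a stated time of 48 h (a lower number here means a stronger inhibitor, a higher number a weaker inhibitor), compound 1 (`COc1cc(-c2ccnc3cc(-c4c[nH]c5ccccc45)nn23)cc(OC)c1OC`) gives 195 nM, the lowest of the three numbers so far. Compound 2 (`COc1cc(-c2ccnc3cc(-c4ccc(Cl)cc4)nn23)cc(OC)c1OC`) gives 1490 nM, and compound 3 (`Cn1ccc2cc(-c3cc4nccc(-c5ccc(F)cc5)n4n3)ccc21`) gives 5210 nM. Compound 4 (`COc1cc(-c2ccnc3cc(-c4ccc5c(ccn5C)c4)nn23)cc(OC)c1OC`) keeps the core of compound 1 and changes one group: 1-methyl-1H-indol-5-yl in place of 1H-indol-3-yl on an aromatic carbon. The new group is still an indole, but it is attached differently and carries a methyl on its nitrogen.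

For the measured compounds named here, only one measured step touches this place: a 7.6-fold higher number from compound 1 to compound 2 (0.88 log units; beyond the scatter), a modest change beyond the scatter. That step replaces the indole with a 4-chlorophenyl, so it shows that this place matters but not how an indole-for-indole swap will behave. Compound 3 also carries 1-methyl-1H-indol-5-yl, but it differs from compound 4 elsewhere, so it offers no clean comparison.

With no firm direction, the estimated change is a 1.1-fold lower number from compound 1 to compound 4 (0.06 log units; within the scatter), no step beyond the scatter. Compound 4 is expected at about 170 nM, with an estimated range from 35 nM to 850 nM.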

Compound 4, half-maximal inhibitory concentration: 19 nM
Compound 4: middle estimate off by 8.9-fold (0.95 log units), on the high side; the measured number lies below the stated range.
By their numbers in this assay, from the lowest: compound 4; then compound 1; then compound 2; then compound 3.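

In this assay, exchanging one indole for another at this position is far from neutral: putting 1-methyl-1H-indol-5-yl in place of 1H-indol-3-yl gives a 10-fold lower number from compound 1 to compound 4 (1.01 log units; beyond the scatter). The position therefore distinguishes between two indoles, not only between an indole and a 4-chlorophenyl, and the new group also gives a 78-fold lower number from compound 2 to compound 4 (1.89 log units; beyond the scatter). Nothing shown explains why this change has such an effect.

Two things change together in this step, the way the indole is attached and the methyl on its nitrogen, and the compounds shown do not separate them. As far as these compounds go, it also remains open how this place would respond to a longer chain on the indole nitrogen, such as an ethyl or propyl group, or to an amine on the indole.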